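Isobutylsulfonyl in place of (2-hydroxyethyl)sulfonyl on compound 1

This account rests on a few compounds, and the source may have more. Where it says the series, first, only, none or still open, it means among the compounds named here.

Measured compounds:
- compound 1, `Cc1ccc(S(=O)(=O)CCO)cc1C#Cc1cc(Cl)ccc1OCC(=O)O`: 19 nM
- compound 2, `CCCS(=O)(=O)c1ccc(F)c(C#Cc2cc(Cl)ccc2OCC(=O)O)c1`: 3.4 nM
- compound 3, `CS(=O)(=O)c1ccc(C#Cc2cc(Cl)ccc2OCC(=O)O)cc1`: 86 nM

All three were tested in an assay on CHO cells for displacement of a labelled ligand from prostaglandin D2 receptor 2 (Homo sapiens), read by scintillation counting; on this read-out lower numbers stand for stronger inhibition and higher numbers for weaker inhibition. Compound 1 gives 19 nM, which is the second highest of the three numbers. Its nearest neighbour is compound 3, whose 86 nM is a higher number and therefore a weaker binder, with a gap beyond the scatter. Furthest away is compound 2, whose 3.4 nM is a lower number and so a stronger binder, again beyond the scatter. No two of these compounds differ in only one place, so no single step can be read from them.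

Compound 4, `Cc1ccc(S(=O)(=O)CC(C)C)cc1C#Cc1cc(Cl)ccc1OCC(=O)O`, has not yet been measured. It is compound 1 with one change: isopropyl in place of hydroxymethyl on a saturated chain carbon bound to a sulfonyl sulfur. In other words, a (2-hydroxyethyl)sulfonyl becomes an isobutylsulfonyl; the rest of the molecule is untouched.

Without a measured step of this kind, the expectation is loose. Because compound 2, which carries a propylsulfonyl chain without a hydroxyl, gives 3.4 nM, a modest move toward a lower number is expected, but one that may still sit within the scatter. Compound 4 is estimated at 10 nM, with a range from 3 nM to 35 nM, meaning an expected step of a 1.9-fold lower number from compound 1 to compound 4 (0.28 log units; within the scatter).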

Compound 4, inhibition constant: 3 nM
Compound 4: the middle estimate sits 3.3-fold (0.52 log units) above what was measured; the range from low to high includes it.
By their numbers in this assay, from the lowest: compounds 4 and 2 (each within the scatter of the next); then compound 1; then compound 3.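

In this assay, among these compounds, putting isopropyl in place of hydroxymethyl on a saturated chain carbon bound to a sulfonyl sulfur gives a 6.3-fold lower number from compound 1 to compound 4 (0.80 log units; beyond the scatter), the first single-place change that can be read in this set. The step lies beyond the scatter, and it shows that the end of this chain does not need its hydroxyl for strong binding in this series: the hydrogen-bond donor and acceptor counted on hydroxymethyl are gone, and the number still falls. Nothing measured here shows why this happens.

This one change removes the hydroxyl and adds carbon at the same time, and the compounds shown do not tell these two parts apart. An ethyl chain on the sulfonyl would remove the hydroxyl with no added carbon, a longer chain or a cyclopropylmethyl group would show how much more size this position accepts, and an amine at the chain end would test a different kind of group there.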